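Swapping Chlorophenyl for Thiophene: Expected Effect on Clearance

The compounds below may be only part of what the source reports. "The series", "measured", "known", "first", "only" and "open" are said of these compounds alone.

Compound 2 `COc1cc(NC(C)CCCNC(=O)C2CCC3(CC2)OOC2(OO3)C3CC4CC(C3)CC2C4)c2ncccc2c1-c1ccc(Cl)cc1` was examined in an ADME assay on microsomes from liver (Rattus norvegicus) for metabolic stability, read by HPLC, using NADPH, tested at 1 mM (on this read-out higher numbers stand for fast clearance and lower numbers for slow clearance), where compound 2 gives 10.7 uL/min. That is the lowest of the two numbers measured here; the nearest is compound 1 `COc1cc(NC(C)CCCNC(=O)C2CCC3(CC2)OOC2(OO3)C3CC4CC(C3)CC2C4)c2ncccc2c1-c1ccccc1`, which in this assay gives 33 uL/min. Going by the values given here, the only measured step is a 3.1-fold lower number from compound 1 to compound 2 (0.49 log units; beyond the scatter). Compound 3 `COc1cc(NC(C)CCCNC(=O)C2CCC3(CC2)OOC2(OO3)C3CC4CC(C3)CC2C4)c2ncccc2c1-c1ccsc1` has not yet been measured; it differs from compound 2 in this way: thiophen-3-yl in place of 4-chlorophenyl on an aromatic carbon. Among the compounds with values here, no measured step covers this exact exchange, so the expectation rests on the one step available. Since compound 3 lacks the chloro that set a 3.1-fold lower number from compound 1 to compound 2 (0.49 log units; beyond the scatter), the number is expected to move partly back up for compound 3, a 2.3-fold higher number from compound 2 to compound 3 (0.37 log units; beyond the scatter). With the whole exchange untested, the uncertainty is wide. Compound 3 is therefore estimated to give 25 uL/min, with a range from 10 uL/min to 60 uL/min.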

Compound 3, intrinsic clearance in a liver preparation (reported as CLH), per the amount of preparation that the assay uses: 37.4 uL/min
The estimate for compound 3 lay 1.5-fold (0.17 log units) below the measured number; low and high end bracket the measured number.
By their numbers in this assay, from the lowest: compound 2; then compounds 1 and 3 (each within the scatter of the next).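

In this assay, thiophen-3-yl in place of 4-chlorophenyl gives a 3.5-fold higher number from compound 2 to compound 3 (0.54 log units; beyond the scatter), so the low number of compound 2 does not carry over to this five-membered ring. Thiophen-3-yl in place of the plain phenyl gives a 1.1-fold higher number from compound 1 to compound 3 (0.05 log units; within the scatter), so these two rings cannot be told apart at this position, and among the three groups tried here only 4-chlorophenyl stands apart. Nothing available explains why compound 2 has the lowest number.

Going by these compounds, whether a chloro on the thiophene ring would lower the number, as it does on the phenyl ring, remains open. Also open, on these data alone, is how a fluoro, a methoxy or an amine would compare with the chloro on the phenyl ring, and how thiophen-2-yl would compare with thiophen-3-yl.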